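The compounds below may be only part of what the source reports. "The series", "measured", "known", "first", "only" and "open" are said of these compounds alone.

Compound 1 `CCOC(=O)c1cc(N)c2nc(-c3ccccc3)cnc2c1`: > 100000 nM
Compound 2 `CCOC(=O)c1cc(N)c2c(c1)NCC(c1ccccc1)=N2`: > 100000 nM

In a functional assay on L1210 cells (Mus musculus) (on this read-out lower numbers stand for stronger inhibition and higher numbers for weaker inhibition), compound 1 gives only a limit of the assay, > 100000 nM. In this assay compound 2 also gives only a limit, > 100000 nM. Going by the values given here, both values shown therefore sit at the same limit (the limit of > 100000 nM in this assay, at which 2 of the 2 values shown sit), and compound 2 stands exactly where the one other measured compound stands, with its true potency unknown beyond that boundary.

Compound 3 `COC(=O)Nc1cc(N)c2c(c1)NCC(c1ccccc1)=N2` differs from compound 2 in one place: (methoxycarbonyl)amino in place of ethoxycarbonyl on an aromatic carbon. Among the compounds with values here, no step between two measured compounds has been recorded, so nothing measured tells how this exchange acts on potency. From the compounds shown here alone, with both measured compounds at the limit, any outcome remains open; a modest step toward stronger inhibition is expected, an at least 2.0-fold lower number from compound 2 to compound 3 (0.30 log units; that floor lies within the scatter), but with low confidence. Compound 3 is accordingly estimated at 50000 nM, within a range from 2000 nM to 300000 nM.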

Compound 3, half-maximal inhibitory concentration: 24000 nM
Beside the measured number, compound 3's estimate is 2.1-fold (0.32 log units) above it, and the stated range covers the measured number.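

Until now, this assay had returned only limits, so nothing showed that any change on this aromatic carbon could register. Putting (methoxycarbonyl)amino in place of ethoxycarbonyl there gives the first readable step, an at least 4.1-fold lower number from compound 2 to compound 3 (0.61 log units; beyond the scatter), and it lies beyond the usual scatter. That step is only a minimum, because compound 2 has a limit rather than a true number: the limit of > 100000 nM in this assay, at which 2 of the 3 values shown sit.

The exchange alters two things at once, since the entering group brings a nitrogen carrying a hydrogen-bond donor and also has a methyl instead of an ethyl at its end, so the compounds shown cannot separate these two differences. From the compounds shown here alone, it also remains open whether (ethoxycarbonyl)amino, a plain acetylamino group or a carboxylic acid on the same carbon would give stronger or weaker inhibition than compound 3.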